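Furanylmethyl-aminopropylamino quinolines: aryl swap and solubility

The source may report more compounds than this note shows. Statements on the series, on what has been measured and on what is new or still open speak of the compounds shown alone.

Measured so far:
compound 1 `Cc1cc(C)cc(Cc2ccc3c(NCCCNCc4ccco4)ccnc3c2)c1` — 4200 nM
compound 2 `c1coc(CNCCCNc2ccnc3cc(-c4cccc5ccccc45)ccc23)c1` — 32000 nM

Going by the values given here, in a physicochemical assay for solubility, with a stated time of 18 h, at pH 7.4 (on this read-out higher numbers stand for higher solubility and lower numbers for lower solubility), compound 2 gives 32000 nM, the higher of the two numbers so far; compound 1 stands below it by a 7.6-fold higher number from compound 1 to compound 2 (0.88 log units; beyond the scatter), the only step measured. Compound 3 `Clc1ccc(Oc2ccc3c(NCCCNCc4ccco4)ccnc3c2)cc1` differs from compound 2 by 4-chlorophenoxy in place of naphthalen-1-yl on an aromatic carbon. Among the compounds with values here, no measured step covers this change: the one available step exchanges 3,5-dimethylbenzyl for naphthalen-1-yl and bears on the present replacement only in that the same aromatic carbon is again varied. Within the data shown here, the size of that step, modest and beyond the scatter, is the sole guide to how much this position can move this assay. Compound 3 is therefore expected to stay near compound 2, with a step of a 1.6-fold lower number from compound 2 to compound 3 (0.20 log units; within the scatter) and wide uncertainty. Compound 3 is estimated at 20000 nM, between 5000 nM and 60000 nM.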

Compound 3, solubility: 14500 nM
Beside the measured number, compound 3's estimate is 1.4-fold (0.14 log units) above it; low and high end bracket the measured number.
By their numbers in this assay, from the lowest: compound 1; then compound 3; then compound 2.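

With a third group on this aromatic carbon, this assay shows a graded range rather than a single change: 4-chlorophenoxy in place of naphthalen-1-yl gives a 2.2-fold lower number from compound 2 to compound 3 (0.34 log units; beyond the scatter), while 4-chlorophenoxy in place of 3,5-dimethylbenzyl gives a 3.5-fold higher number from compound 1 to compound 3 (0.54 log units; beyond the scatter). Compound 3 therefore takes the middle place of the three, so a group with one aromatic ring and one hydrogen-bond acceptor does not match naphthalen-1-yl here, yet stays clearly apart from 3,5-dimethylbenzyl. Nothing available explains this order of the three groups.

Open, going by these compounds, is whether the chlorine or the oxygen link carries the difference, which plain phenoxy or 4-chlorophenyl on the same carbon would separate. Also open, on these data alone, is how an amine or a carboxylic acid at this position would read in this assay, and whether the order of the three groups holds with a longer chain on the shared core.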